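Replacing a fluorophenyl by naphthalenyl on the shared core

The source may report more compounds than this note shows. Statements on the series, on what has been measured and on what is new or still open speak of the compounds shown alone.

Measured compounds:
- compound 1, `N#CC1=C(N)OC(c2c[nH]c3ccccc23)=C(C#N)C1c1ccccc1F`: "not active" (no number reported)
- compound 2, `N#CC1=C(N)OC(c2c[nH]c3ccccc23)=C(C#N)C1c1ccccc1Cl`: 21.4%
- compound 3, `N#CC1=C(N)OC(c2c[nH]c3ccccc23)=C(C#N)C1c1ccc(F)cc1`: 26.7%

In a functional assay, tested at 400 ug/mL (on this read-out lower numbers stand for a weaker effect and higher numbers for a stronger effect at the one concentration tested), compound 1 is reported only as "not active" (no number reported), with no number attached, so it stands below the two compounds that do carry a number. Compound 4, `N#CC1=C(N)OC(c2c[nH]c3ccccc23)=C(C#N)C1c1cccc2ccccc12`, has not yet been measured. It differs from compound 1 in one place: naphthalen-1-yl in place of 2-fluorophenyl on a saturated ring carbon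

For the measured compounds named here, only one measured step exists, and it swaps one halogenated phenyl for another on the same saturated ring carbon: a number 5.3 percentage points higher from compound 2 to compound 3 (within the scatter). That step does not introduce a second aromatic ring, so it does not speak directly to the change from compound 1 to compound 4. What the data show is that compounds 2 and 3, which keep a single six-membered ring there, give modest read-outs, while compound 1 gives none. Going by the values given here, with no step of the right kind to lean on, a modest read-out near those of compound 2 and compound 3 is the most defensible expectation for compound 4. Compound 4 is therefore estimated at 20%, with a range from 0% to 45%.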

Compound 4, a percentage reported as activity, at one concentration (the size of the read-out at that concentration, not a potency): 10.4%
Beside the measured number, compound 4's estimate is 9.6 percentage points above it, and the stated range covers the measured number.
By their numbers in this assay, from the lowest: compound 4; then compounds 2 and 3 (each within the scatter of the next).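

Placing naphthalen-1-yl on the saturated ring carbon gives, in this assay, a number 16.3 percentage points lower from compound 3 to compound 4 (beyond the scatter) and a number 11 percentage points lower from compound 2 to compound 4 (beyond the scatter). This position can therefore carry a second aromatic ring and still give a number, while compound 1, with 2-fluorophenyl in the same place, is reported as "not active" (no number reported); with no number for compound 1, the size of that step cannot be read. Nothing available here accounts for these differences.

Going by these compounds, it remains open whether naphthalen-2-yl would give a read-out like that of naphthalen-1-yl, and whether a non-aromatic group such as cyclohexyl would keep any effect at this carbon. A phenyl bearing an amine or a carboxylic acid is also untested in the compounds shown, and a single concentration says nothing about potency.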